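Swapping the aryl group on the hydrazone carbon once more

The compounds below may be only part of what the source reports. "The series", "measured", "known", "first", "only" and "open" are said of these compounds alone.

For the measured compounds named here, compound 2 `Cc1cc(/C=N/NC(=O)Nc2ccc(Oc3ccnc(-c4nncn4CCN(C)C)c3)c(F)c2)cc(C)c1O` is one of two compounds measured in a functional assay on MKN-45 cells (Homo sapiens) for cytotoxicity, read by MTT assay, with a stated time of 72 h (on this read-out higher numbers stand for weaker inhibition and lower numbers for stronger inhibition), where compound 2 gives 1510 nM. The other is compound 1 `CN(C)CCn1cnnc1-c1cc(Oc2ccc(NC(=O)N/N=C/c3ccc(F)cc3Cl)cc2F)ccn1`, and in this assay compound 1 gives 870 nM; the two numbers sit within the scatter of each other. Compound 3 `COc1ccc(/C=N/NC(=O)Nc2ccc(Oc3ccnc(-c4nncn4CCN(C)C)c3)c(F)c2)c(OC)c1` has not yet been measured. It differs from compound 2 in a single place: 2,4-dimethoxyphenyl in place of 4-hydroxy-3,5-dimethylphenyl on a carbon with a double bond to nitrogen. Going by the values given here, the one step already seen at this same position, a 1.7-fold higher number from compound 1 to compound 2 (0.24 log units; within the scatter), changed the aryl group on the carbon with a double bond to nitrogen and moved the number only within the scatter. With a single precedent of that kind, a further aryl swap at the same place is expected to give a step of a 1.1-fold lower number from compound 2 to compound 3 (0.03 log units; within the scatter), that is, none beyond the scatter. Compound 3 is therefore expected to give about 1400 nM, with a likely range from 600 nM to 3500 nM.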

Compound 3, half-maximal inhibitory concentration: 1680 nM
Compound 3: middle estimate off by 1.2-fold (0.08 log units), on the low side; the measured number falls inside the stated range.
By their numbers in this assay, from the lowest: compounds 1, 2 and 3 (each within the scatter of the next).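

Replacing 4-hydroxy-3,5-dimethylphenyl, with 1 hydrogen-bond donor, by 2,4-dimethoxyphenyl, with 0 hydrogen-bond donors, on the carbon with a double bond to nitrogen gives in this assay a 1.1-fold higher number from compound 2 to compound 3 (0.05 log units; within the scatter) and so shows that this change in donor count comes with no shift beyond the scatter. The largest step among these compounds, a 1.9-fold higher number from compound 1 to compound 3 (0.29 log units; within the scatter) and thus no more than scatter, means that the three aryl groups cannot be told apart in this assay. Nothing available explains why the numbers stay so close.

All three groups at this position are aromatic rings of carbon only. Going by these compounds, whether the number would move with something quite different there, such as a carboxylic acid, an amine or a short alkyl chain, remains open.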